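This account rests on a few compounds, and the source may have more. Where it says the series, first, only, none or still open, it means among the compounds named here.

Working notes on the series. In a physicochemical assay for acid dissociation, compound 1 `COc1ccccc1Oc1ccc2c(NCCCNCc3ccco3)ccnc2c1` gives 9.28, compound 2 `COc1ccc(-c2ccc3c(NCCCNCc4ccco4)ccnc3c2)cc1` gives 9.47, and compound 3 `FC(F)(F)c1ccc(-c2ccc3c(NCCCNCc4ccco4)ccnc3c2)cc1` gives 9.47. Compound 3 stands level with compound 2 at the digits shown, the two together at the top of the three numbers, and the remaining step is a number 0.19 log units higher from compound 1 to compound 3 (within the scatter). The next change is naphthalen-1-yl in place of 4-(trifluoromethyl)phenyl on an aromatic carbon, giving compound 4 `c1coc(CNCCCNc2ccnc3cc(-c4cccc5ccccc45)ccc23)c1`. The step that bears most directly on it is no change at the digits printed from compound 2 to compound 3 (within the scatter), and a number 0.19 log units higher from compound 1 to compound 2 (within the scatter) likewise stayed within the scatter, so a step of a number 0.02 log units lower from compound 3 to compound 4 (within the scatter) is expected, none beyond the scatter. For compound 4 the estimate in this assay is 9.45, with a range from 9.15 to 9.75.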

Compound 4, acid dissociation constant: 9.47
Estimate against measurement, compound 4: 0.02 log units below, and the stated range covers the measured number.
By their numbers in this assay, from the lowest: compounds 1, 2, 3 and 4 (each within the scatter of the next).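

In this assay naphthalen-1-yl, with its two six-membered aromatic rings of carbon only and no fluorine, gives no change at the digits printed from compound 3 to compound 4 (within the scatter) and also no change at the digits printed from compound 2 to compound 4 (within the scatter) in the comparison with 4-methoxyphenyl. The comparison with 2-methoxyphenoxy gives a number 0.19 log units higher from compound 1 to compound 4 (within the scatter) and so all four groups at this position lie within the scatter of one another. Nothing available here accounts for this reading.

As far as these compounds go, whether an amine or a carboxylic acid on this aromatic carbon would move the number stays open.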